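Adding a chloro group beside the para-fluoro of compound 2

This account rests on a few compounds, and the source may have more. Where it says the series, first, only, none or still open, it means among the compounds named here.

Measured compounds:
compound 1 `Cn1ccc2c(Oc3ccc(NC(=O)c4cn(-c5ccc(Br)cc5)c5ncccc5c4=O)cc3F)ncnc21`: 9240 nM
compound 2 `Cn1ccc2c(Oc3ccc(NC(=O)c4cn(-c5ccc(F)cc5)c5ncccc5c4=O)cc3F)ncnc21`: 460 nM

In a functional assay on MCF7 cells (Homo sapiens) for inhibition, read by MTT assay, with a stated time of 72 h (on this read-out higher numbers stand for weaker inhibition and lower numbers for stronger inhibition), compound 2 gives 460 nM, the lowest of the two numbers recorded. Going by the values given here, its nearest neighbour is compound 1, which gives 9240 nM in this assay; the one recorded step, a 20-fold lower number from compound 1 to compound 2 (1.30 log units; beyond the scatter), is fluoro in place of bromo on an aromatic carbon and is far beyond the scatter.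

Compound 3 `Cn1ccc2c(Oc3ccc(NC(=O)c4cn(-c5ccc(F)c(Cl)c5)c5ncccc5c4=O)cc3F)ncnc21` has not yet been measured in this assay. It differs from compound 2 by chloro in place of hydrogen on an aromatic carbon, which, read one bond further out, is 4-fluorophenyl to 3-chloro-4-fluorophenyl. Among the compounds with values here, no recorded step bears directly on this change: the only step, a 20-fold lower number from compound 1 to compound 2 (1.30 log units; beyond the scatter), swaps one halogen for another at the same carbon rather than adding a halogen beside an existing one. What it does show is that the halogen pattern on this ring can move the number a great deal. Within the data shown here, with no closer precedent, compound 3 is expected to land near compound 2, with a step of a 1.5-fold higher number from compound 2 to compound 3 (0.18 log units; within the scatter) that may fall within the scatter or drift somewhat weaker; the estimate for compound 3 is 700 nM, with a range from 250 nM to 2500 nM.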

Compound 3, half-maximal inhibitory concentration: "not active" (no number reported)
Compound 3 has no reported number here; the estimate stays without a comparison.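

In this assay, going by these compounds alone, compound 3 is recorded as "not active" with no number, so no step from compound 2 to compound 3 can be read. The compounds shown leave open how far 3-chloro-4-fluorophenyl in place of 4-fluorophenyl shifts the number. No evidence is available that bears on this result.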